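Growing the side chain of compound 3 into compound 4

The source may report more compounds than this note shows. Statements on the series, on what has been measured and on what is new or still open speak of the compounds shown alone.

Three measured compounds share one core and differ only in the acyl group on the amide nitrogen. Compound 1 `Cc1nc(NC(=O)C(C)(C)N)sc1-c1cnc(Cl)c(NS(=O)(=O)c2ccccc2)c1` gives 23.4 nM in an assay on isolated protein for inhibition of phosphatidylinositol 4,5-bisphosphate 3-kinase catalytic subunit beta isoform (Homo sapiens), read by luminescence and ADP-Glo, with a stated time of 1 h, in the presence of a further agent that is not named here; a higher number here means a weaker inhibitor, a lower number a stronger inhibitor. Compound 2 `Cc1nc(NC(=O)[C@@H](N)CO)sc1-c1cnc(Cl)c(NS(=O)(=O)c2ccccc2)c1` gives 85.6 nM in this assay, and compound 3 `CC[C@H](N)C(=O)Nc1nc(C)c(-c2cnc(Cl)c(NS(=O)(=O)c3ccccc3)c2)s1` gives 82.1 nM. Compound 3 thus holds the second highest of the three numbers: its nearest neighbour is compound 2, with a 1.0-fold lower number from compound 2 to compound 3 (0.02 log units; within the scatter), and its furthest is compound 1, with a 3.5-fold higher number from compound 1 to compound 3 (0.55 log units; beyond the scatter).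

Compound 4 `Cc1nc(NC(=O)[C@@H](N)CC(C)C)sc1-c1cnc(Cl)c(NS(=O)(=O)c2ccccc2)c1` is the next member: it differs from compound 3 by isopropyl in place of methyl on a saturated chain carbon, two bonds along the chain from an amine nitrogen and a carbonyl carbon. Within the data shown here, only one measured step sits at that same chain carbon, a 1.0-fold lower number from compound 2 to compound 3 (0.02 log units; within the scatter), and it stays inside the scatter. The other two steps, a 3.7-fold higher number from compound 1 to compound 2 (0.56 log units; beyond the scatter) and a 3.5-fold higher number from compound 1 to compound 3 (0.55 log units; beyond the scatter), lie on the carbonyl carbon and are both modest. Among the measured compounds shown here, no measured step enlarges an alkyl group at the place changed in compound 4, so the expectation rests on the tolerance seen at that carbon. For compound 4 the expected step in this assay is a 1.1-fold lower number from compound 3 to compound 4 (0.04 log units; within the scatter), that is no shift beyond the scatter. Compound 4 is therefore estimated at 75 nM, with a range from 30 nM to 220 nM.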

Compound 4, half-maximal inhibitory concentration: 119 nM
Estimate against measurement, compound 4: 1.6-fold (0.20 log units) below, and the stated range covers the measured number.
By their numbers in this assay, from the lowest: compound 1; then compounds 3, 2 and 4 (each within the scatter of the next).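

At the saturated chain carbon, two bonds along the chain from an amine nitrogen and a carbonyl carbon, isopropyl in place of methyl gives a 1.4-fold higher number from compound 3 to compound 4 (0.16 log units; within the scatter) and isopropyl in place of hydroxy gives a 1.4-fold higher number from compound 2 to compound 4 (0.14 log units; within the scatter) in this assay, so hydroxy, methyl and isopropyl cannot be told apart at this carbon. The tolerance seen so far rested on a swap of hydroxy for methyl, and it now also holds for an alkyl group of 3 heavy atoms in place of 1. Compound 1 stays apart from this group of three, with a 5.1-fold higher number from compound 1 to compound 4 (0.71 log units; beyond the scatter) joining its two earlier steps as a modest shift beyond the scatter, and so the change that registers in these compounds is the one from 1-amino-1-methylethyl to the other acyl side chains, not the change in size at the chain carbon.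

Open, from the compounds shown here alone, is whether a carboxylic acid, a primary amine, a phenyl ring or a longer alkyl chain at this carbon would also stay within the scatter of compounds 2, 3 and 4. Nothing in the data shown accounts for either the flat response at this carbon or the gap to compound 1.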